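This account rests on a few compounds, and the source may have more. Where it says the series, first, only, none or still open, it means among the compounds named here.

Measured compounds:
compound 1 `Cn1c(=O)c2ccccc2c(=O)n1CCCNC(=O)OC(C)(C)C`, 3960 nM in a functional assay on aorta (Rattus norvegicus, strain Wistar) for inhibition; a higher number here means that more compound is needed for the effect, a lower number that less compound is needed
compound 2 `Cn1c(=O)c2cccc(Cl)c2c(=O)n1CCCNC(=O)OC(C)(C)C`, 4780 nM
compound 3 `Cn1c(=O)c2c(Cl)cccc2c(=O)n1CCCN`, 8510 nM

Compound 2 sits within the scatter of both others: the gap to compound 1 is small, and the gap to compound 3 is also within the scatter. Among the measured compounds shown here, the one single-point step, a 1.2-fold higher number from compound 1 to compound 2 (0.08 log units; within the scatter), concerns a chloro for hydrogen and says nothing about the chain end. Compound 4 `Cn1c(=O)c2cccc(Cl)c2c(=O)n1CCCBr` is the unmeasured compound; the change is bromo in place of (tert-butoxycarbonyl)amino on a saturated chain carbon, three bonds along the chain from an aromatic nitrogen. For the measured compounds named here, no measured step bears on this change; compound 3 carries a different chain end and a different chloro position, so its value with that of compound 2 shows only two numbers within the scatter. A step of the size of the scatter or somewhat beyond, toward a higher number, is expected, written as a 1.4-fold higher number from compound 2 to compound 4 (0.13 log units; within the scatter). Compound 4 is therefore estimated at 6500 nM, with a range from 2500 nM to 17000 nM.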

Compound 4, half-maximal effective concentration: 3360 nM
Estimate against measurement, compound 4: 1.9-fold (0.29 log units) above; the range from low to high includes it.
By their numbers in this assay, from the lowest: compounds 4, 1, 2 and 3 (each within the scatter of the next, the first and the last beyond it).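

Among the compounds shown here, the step of a 1.4-fold lower number from compound 2 to compound 4 (0.15 log units; within the scatter) in this assay is the first reading at this chain end. Replacing (tert-butoxycarbonyl)amino, with its 8 heavy atoms, hydrogen-bond donor and two hydrogen-bond acceptors, by the single heavy atom of bromo leaves the number within the scatter. The bulk of that group and its donor and acceptors are therefore not required for a value of this size, and nothing available explains this result.

Still open, from the compounds shown here alone, is whether a carboxylic acid on this carbon, or a longer chain carrying bromo, would move the number beyond the scatter.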